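This account rests on a few compounds, and the source may have more. Where it says the series, first, only, none or still open, it means among the compounds named here.

Within the data shown here, in an assay on isolated protein for inhibition of DNA topoisomerase 1 (Homo sapiens), with a stated time of 30 min, tested at 100 uM (a higher number here means a stronger effect of the compound at the concentration tested, a lower number a weaker effect), compound 2 `Oc1cccc(-c2cc(-c3cccs3)cc(-c3cccc(O)c3)n2)c1` gives 91.7%, the higher of the two numbers known here. Compound 1 `Oc1ccc(-c2cc(-c3cccs3)cc(-c3ccccc3O)n2)cc1` gives 72.2% in this assay, a value that lies beyond the scatter below that of compound 2. Compound 3 `Oc1ccc(-c2cc(-c3cccs3)cc(-c3cccc(O)c3)n2)cc1` has not yet been measured in this assay. It differs from compound 2 in one place: 4-hydroxyphenyl in place of 3-hydroxyphenyl on an aromatic carbon. Compound 1 carries two 4-hydroxyphenyl groups and compound 2 two 3-hydroxyphenyl groups, so compound 3, with one of each, stands between them in structure. Because compound 1 gives 72.2% and compound 2 gives 91.7%, a step downward from compound 2 is expected. Compound 3 is estimated at 82% in this assay, with a range from 68% to 93%. The expected step is a number 9.7 percentage points lower from compound 2 to compound 3 (within the scatter).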

Compound 3, a percentage reported as inhibition, at one concentration (the size of the read-out at that concentration, not a potency): 85.7%
The estimate for compound 3 lay 3.7 percentage points below the measured number; the measured number falls inside the stated range.
By their numbers in this assay, from the lowest: compound 1; then compounds 3 and 2 (each within the scatter of the next).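

In this assay, 4-hydroxyphenyl in place of 3-hydroxyphenyl on the aromatic carbon next to the ring nitrogen gives a number 6 percentage points lower from compound 2 to compound 3 (within the scatter), so this read-out does not tell the two groups apart at this position. The second change, 3-hydroxyphenyl in place of 2-hydroxyphenyl, gives a number 13.5 percentage points higher from compound 1 to compound 3 (beyond the scatter), and it is the only single change among these compounds that lies beyond the scatter. No measurement given here accounts for either step.

On these data alone, all three compounds carry only hydroxyphenyl groups at the varied places and share the thiophen-2-yl group, so it remains open how a methoxyphenyl group, an aminophenyl group or a carboxylic acid would read there. A single tested concentration also leaves their potencies open.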